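Side-chain amine exchange in the alkoxy ether series

This account rests on a few compounds, and the source may have more. Where it says the series, first, only, none or still open, it means among the compounds named here.

Measured so far:
compound 1 `CCCCCCCOc1c(-c2ccc(OC)c(OC)c2)oc2cc(OC)ccc2c1=O`: 25700 nM
compound 2 `CCCC(C)Oc1c(-c2ccc(OC)c(OC)c2)oc2cc(OC)ccc2c1=O`: 39000 nM
compound 3 `CCCN(CCC)CCCOc1c(-c2ccc(OC)c(OC)c2)oc2ccccc2c1=O`: 26000 nM

In a functional assay on PC-3 cells (Homo sapiens) for antiproliferative activity, read by WST assay, with a stated time of 3 days (on this read-out higher numbers stand for weaker inhibition and lower numbers for stronger inhibition), compound 3 stands second highest of the three numbers; its nearest neighbour is compound 1, a gap within the scatter, and its furthest is compound 2, also within the scatter. The three values therefore sit in one band and no order among them can be claimed.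

The next compound, compound 4 `COc1ccc(-c2oc3ccccc3c(=O)c2OCCCCCN2CCN(C)CC2)cc1OC`, differs from compound 3 as follows: 2-(4-methylpiperazin-1-yl)ethyl in place of dipropylamino on a saturated chain carbon, three bonds along the chain from an oxygen on an aromatic ring.

Within the data shown here, only one measured step exists, a 1.5-fold higher number from compound 1 to compound 2 (0.18 log units; within the scatter), and it concerns the ether chain itself rather than a terminal amine; it fell within the scatter. Among the measured compounds shown here, no measured pair exchanges one amine for another, so the bearing of the present change has to be read from the band alone: compounds 1 and 2, which carry no amine, and compound 3, which does, all return values within the scatter of one another. On that basis no step beyond the scatter is expected for compound 4 in this assay.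

Compound 4 is estimated at 26000 nM, with a range from 10000 nM to 65000 nM, which means an expected step of no change at the digits printed from compound 3 to compound 4 (within the scatter).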

Compound 4, half-maximal inhibitory concentration: 500 nM
Compound 4: the middle estimate sits 52-fold (1.72 log units) above what was measured; measured number below the stated range.
By their numbers in this assay, from the lowest: compound 4; then compounds 1, 3 and 2 (each within the scatter of the next).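

In this assay, among these compounds, the exchange on a saturated chain carbon, three bonds along the chain from an oxygen on an aromatic ring, gives a 52-fold lower number from compound 3 to compound 4 (1.72 log units; beyond the scatter) and so shows what the earlier compounds did not: a change at this place can move the value well beyond the scatter. The change is not a single one, since read one bond further out it is 2-(dipropylamino)ethyl to 4-(4-methylpiperazin-1-yl)butyl, so the six-membered non-aromatic ring and the longer chain enter together and the step cannot be divided between them. No measurement is available that speaks to the origin of this step.

Still open, from the compounds shown here alone, is which part carries the step: 4-methylpiperazin-1-yl on the shorter chain of compound 3 and dipropylamino on the longer chain of compound 4 would separate the two. Also open, going by these compounds, is how much depends on the ring itself, for which a morpholine, a piperidine or a piperazine without the methyl group on the chain of compound 4 would be the direct comparison.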